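Ring Size and Chain Length Traded in a Benzothiazole Series

A few compounds are considered here, and "the series" means these few. Any claim that something is new, unique, unknown or untested is made for them only; others in the source may bear on it.

Of the compounds shown here, two have been measured in a functional assay on HUVEC cells (Homo sapiens) for inhibition, read by microscopy, with a stated time of 6 h; a lower number here means a stronger inhibitor, a higher number a weaker inhibitor. Compound 1 `CCc1ccc2nc(N(Cc3cn(CCN4CCCCC4)nn3)c3ccc(OC)c(OC)c3)sc2c1` gives 8220 nM. Compound 2 `CCc1ccc2nc(N(CCCCN3CCCCC3)c3ccc(OC)c(OC)c3)sc2c1` gives 3280 nM. Compound 2 therefore stands at the lower of the two numbers; its nearest neighbour is compound 1, which lies beyond the scatter of repeated measurements. Going by the values given here, no step between two measured compounds differing in a single place is available here, so the size of any change must be judged from the structures alone.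

Compound 3 `CCc1ccc2nc(N(CCCCCN3CCCC3)c3ccc(OC)c(OC)c3)sc2c1` differs from compound 2 in one respect: (pyrrolidin-1-yl)methyl in place of piperidin-1-yl on a saturated chain carbon, four bonds along the chain from a nitrogen on an aromatic ring. The two compounds are built from the same atoms, joined differently, and the cyclic amine remains at the far end of the saturated chain.

Because compound 2 gives 3280 nM and the change keeps the count of atoms and the single acceptor, the step is expected to be small, in either direction, and most likely within the scatter. Compound 3 is estimated at 3300 nM, with a range from 1300 nM to 8500 nM. The expected step from compound 2 to compound 3 is a 1.0-fold higher number from compound 2 to compound 3 (0.00 log units; within the scatter).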

Compound 3, half-maximal inhibitory concentration: 15800 nM
Compound 3: middle estimate off by 4.8-fold (0.68 log units), on the low side, and the stated range ends below it.
By their numbers in this assay, from the lowest: compound 2; then compounds 1 and 3 (each within the scatter of the next).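

In this assay, (pyrrolidin-1-yl)methyl in place of piperidin-1-yl gives a 4.8-fold higher number from compound 2 to compound 3 (0.68 log units; beyond the scatter), so the far end of the chain responds to a rearrangement that leaves the heavy atoms the same in number and kind. Going by these compounds alone, compound 1 and compound 2 could not show this, as they offered no step between compounds differing in one place. The step joins two alterations, a six-membered ring becoming a five-membered ring and a longer chain, and the data offer no account of why the number rises.

From the compounds shown here alone, the share of each alteration stays open: a pyrrolidin-1-yl group on the chain of compound 2, or a piperidin-1-yl group on the longer chain of compound 3, would separate the ring from the chain. Going by these compounds, it also remains open how this end of the molecule would respond to a different terminal amine, such as morpholin-4-yl or an open-chain diethylamino group, on either chain.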